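Pyrrolidinium for piperazinium on the heptyl chain

The compounds below may be only part of what the source reports. "The series", "measured", "known", "first", "only" and "open" are said of these compounds alone.

Measured compounds, with their values in an assay on LX2 cells for inhibition of COL1A1 promoter (Homo sapiens), read by a luciferase reporter, with a stated time of 24 h, tested at 50 uM; on this read-out higher numbers stand for a stronger effect at the one concentration tested and lower numbers for a weaker effect:
compound 1 `CN1CC[N+](C)(CCCCCCCOc2ccc(-n3cc(C(=O)Nc4cc(F)cc(F)c4)c(=O)c4ccc(N(C)C)nc43)cc2Cl)CC1` gives 15.4%
compound 2 `Cc1ccc(-n2cc(C(=O)Nc3cc(F)cc(F)c3)c(=O)c3ccc(N(C)C)nc32)cc1OCCCCCCC[N+]1(C)CCN(C)CC1` gives 25%
compound 3 `CC[N+]1(CCCCCCCOc2ccc(-n3cc(C(=O)Nc4cc(F)cc(F)c4)c(=O)c4ccc(N(C)C)nc43)cc2Cl)CCCC1` gives 23.5%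

Compound 1 and compound 3 share one core and differ only at the end of the chain: a group of 7 heavy atoms (6 carbon, 1 nitrogen; one five-membered non-aromatic ring with 1 hetero atom) in place of a group of 8 heavy atoms (6 carbon, 2 nitrogen; one six-membered non-aromatic ring with 2 hetero atoms), on a saturated chain carbon, seven bonds along the chain from an oxygen on an aromatic ring. The step this change made in this assay is a number 8.1 percentage points higher from compound 1 to compound 3 (within the scatter), so it did not move the read-out beyond what repeated runs would give.

Compound 2 carries a different core; the difference between the core of compound 1 and the core of compound 2 is not broken down here. Compound 2 and compound 3 give values that lie within the scatter of each other, as do compound 1 and compound 2, so no order among the three is supported.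

Compound 4 `CC[N+]1(CCCCCCCOc2cc(-n3cc(C(=O)Nc4cc(F)cc(F)c4)c(=O)c4ccc(N(C)C)nc43)ccc2C)CCCC1` is unmeasured and stands to compound 2 as compound 3 stands to compound 1: a group of 7 heavy atoms (6 carbon, 1 nitrogen; one five-membered non-aromatic ring with 1 hetero atom) in place of a group of 8 heavy atoms (6 carbon, 2 nitrogen; one six-membered non-aromatic ring with 2 hetero atoms), on a saturated chain carbon, seven bonds along the chain from an oxygen on an aromatic ring. The place of the change is the same in both pairs, so this is the same change. The step from compound 2 to compound 4 in this assay is expected to be a number 5 percentage points higher from compound 2 to compound 4 (within the scatter), resting on the step seen from compound 1 to compound 3, a number 8.1 percentage points higher from compound 1 to compound 3 (within the scatter), which itself lay within the scatter. Compound 4 is therefore estimated at 30%, with a range from 18% to 42%.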

Compound 4, a percentage reported as inhibition, at one concentration (the size of the read-out at that concentration, not a potency): 81.4%
Estimate against measurement, compound 4: 51.4 percentage points below; measured number outside the range, above it.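

In this assay, placing the five-membered non-aromatic ring group on the chain end in place of the six-membered one gave, on the core of compound 2, a number 56.4 percentage points higher from compound 2 to compound 4 (beyond the scatter). The change therefore does not carry from one core to the other at a single size: the same change on two cores in this assay, a number 8.1 percentage points higher (within the scatter) from compound 1 to compound 3 and a number 56.4 percentage points higher (beyond the scatter) from compound 2 to compound 4, 48.3 percentage points apart, beyond the scatter of two such steps
This shows that the size of the step depends on the core across these two pairs, but it does not show which difference between the cores matters, and two pairs set no rule for any further core.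

Open, going by these compounds, is whether the large step on the core of compound 2 is specific to the five-membered ring group, or would also appear with another chain end, such as a trimethylammonium group or a neutral tertiary amine, or with a shorter or longer chain than the heptyl chain. Also open, on these data alone, is how compound 4 behaves at other concentrations, as a reading at one concentration gives no potency.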